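The compounds below may be only part of what the source reports. "The series", "measured", "known", "first", "only" and "open" are said of these compounds alone.

Measured so far: compound 1 `O=c1c([C@@H]2C[C@H](c3ccccc3)ON2c2ccccc2)coc2ccc(F)cc12` gives 49000 nM; compound 2 `COC(=O)[C@@]1(C)C[C@@H](c2coc3ccc(F)cc3c2=O)N(c2ccccc2)O1` gives 31300 nM; compound 3 `Cc1ccc2occ([C@@H]3C[C@H](c4ccccc4)ON3c3ccccc3)c(=O)c2c1` gives > 60000 nM.

All three were tested in a functional assay on PC-3 cells (Homo sapiens) for inhibition, read by sulforhodamine B assay, with a stated time of 48 h; a higher number here means a weaker inhibitor, a lower number a stronger inhibitor. The value of compound 3 is a limit of this assay, not a number. Compound 1 and compound 3 share a core and differ by methyl in place of fluoro on an aromatic carbon; the resulting step, an at least 1.2-fold higher number from compound 1 to compound 3 (0.08 log units; that floor lies within the scatter), has only a floor because of the limit of > 60000 nM in this assay, at which 1 of the 3 values shown sits. Compound 2 carries a different core, and the difference between the two cores is not broken down here; its value and that of compound 1 lie within the scatter of each other.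

Compound 4 `COC(=O)[C@@]1(C)C[C@@H](c2coc3ccc(C)cc3c2=O)N(c2ccccc2)O1` is not yet measured. It differs from compound 2 by methyl in place of fluoro on an aromatic carbon, the same kind of change that carries compound 1 to compound 3. Placed beside the measured step, the change from compound 2 to compound 4 is expected to give a 1.8-fold higher number from compound 2 to compound 4 (0.24 log units; within the scatter), resting on compound 2 at 31300 nM and on the direction seen in an at least 1.2-fold higher number from compound 1 to compound 3 (0.08 log units; that floor lies within the scatter). In this assay compound 4 is therefore estimated at 55000 nM, with a range from 28000 nM to 150000 nM.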

Compound 4, half-maximal inhibitory concentration: > 60000 nM
Compound 4 ended at the assay's limit; the forecaster's own chance of this, stated with the estimate: 45%; at least 1.0-fold (0.03 log units) between middle value and limit.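

In this assay compound 4 gives > 60000 nM, which is a limit of the assay and not a number. Methyl in place of fluoro on the aromatic carbon gives an at least 1.9-fold higher number from compound 2 to compound 4 (0.28 log units; that floor lies within the scatter), and set beside the same change on the other core, the result reads: the same change on two cores in this assay, an at least 1.2-fold higher number (0.08 log units; that floor lies within the scatter) from compound 1 to compound 3 and an at least 1.9-fold higher number (0.28 log units; that floor lies within the scatter) from compound 2 to compound 4; the limit leaves it open whether they differ. The two cores therefore agree only in that the methyl compound ends at the limit on each, and the series does not show how large the change is on either core or whether it carries over with the same size, because both steps have only a floor: the limit of > 60000 nM in this assay, at which 2 of the 4 values shown sit.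

Among the compounds shown, only fluoro and methyl occupy this aromatic carbon, so it stays open how an amine, a methoxy group or a nitrile there would read in this assay. Going by these compounds, it also stays open whether the change would have a measurable size on a core whose methyl compound gives a value clear of the limit.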